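The source may hold more compounds than are shown below. What is called first, only, known or untested is meant among the compounds shown, and "the series" means these compounds.

Measured compounds:
Compound 1 `CC(=O)c1ccc(NC(=O)Nc2ccc(F)c(C(F)(F)F)c2)cc1`: in an ADME assay on microsomes from liver (Homo sapiens) for metabolic stability, using NADPH, with a stated time of 60 min (on this read-out higher numbers stand for fast clearance and lower numbers for slow clearance), compound 1 gives 16 uL/min.
Compound 2 `N#Cc1ccc(NC(=O)Nc2ccnc(C(F)(F)F)c2)cc1`: in this assay compound 2 gives < 7 uL/min, a limit of the assay rather than a number.
Compound 3 `O=C(Nc1ccc(C(=O)O)cc1)Nc1ccc(F)c(C(F)(F)F)c1`: in this assay compound 3 gives < 7 uL/min, likewise a limit rather than a number.

Compound 3 therefore sits at the limit of this assay. Compound 2 sits at that limit as well. Only compound 1 gives a number, so compound 3 can be placed no more precisely than at the slow end of what has been seen. Among the compounds with values here, the single measured step, an at least 2.2-fold lower number from compound 1 to compound 3 (0.35 log units; beyond the scatter), runs downward and ends on (the limit of < 7 uL/min in this assay, at which 2 of the 3 values shown sit), so its true size is not known.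

Compound 4 `N#Cc1ccc(NC(=O)Nc2ccc(F)c(C(F)(F)F)c2)cc1` differs from compound 3 by cyano in place of carboxy on an aromatic carbon. Within the data shown here, no measured step carries this exact change. Among the measured compounds shown here, compound 2 carries a cyano group on a different core and also returns a limit, while compound 1 carries an acetyl group and is the only compound with a number. For the step from compound 3 to compound 4 a small rise, possibly none beyond the scatter, is therefore expected, with a fair chance that compound 4 also comes back as a limit. Compound 4 is expected near 9 uL/min, between 4 uL/min and 22 uL/min. The step this estimate means is an at least 1.2-fold higher number from compound 3 to compound 4 (0.10 log units; that floor lies within the scatter).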

Compound 4, intrinsic clearance in a liver preparation (reported as CLH), per the amount of preparation that the assay uses: < 7 uL/min
Compound 4: only a limit was reported (the forecaster's own chance of this, stated with the estimate: 45%); middle value at least 1.2-fold (0.10 log units) away from the limit.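

In this assay, cyano in place of acetyl on this aromatic carbon, para to a large group, gives an at least 2.2-fold lower number from compound 1 to compound 4 (0.35 log units; beyond the scatter), which makes cyano the second group at this position, after carboxy, to return a limit rather than a number. Carboxy carries a hydrogen-bond donor and cyano carries none, so among the compounds sharing this core a reading at the limit does not require a donor on this group, and the acetyl group of compound 1 remains the only exception. The direct comparison of compound 3 with compound 4 cannot be read, so no order between carboxy and cyano follows: the limit of < 7 uL/min in this assay, at which 3 of the 4 values shown sit.

From the compounds shown here alone, how far compound 3 and compound 4 lie under that limit remains open, and with it the true size of each drop from compound 1. Also open, going by these compounds, is whether a primary amide or a methyl ester on this aromatic carbon would give a number, as the acetyl group does, or a limit, as carboxy and cyano do.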